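The compounds below may be only part of what the source reports. "The series", "measured", "known", "first", "only" and "open" are said of these compounds alone.

Compound 1 `CCOC(=O)C1=Cc2ccccc2OC1(OCc1cn(-c2cccc(OC)c2)nn1)C(F)(F)F` sits in a functional assay on A549 cells (Homo sapiens) for inhibition, read by MTT assay, with a stated time of 24 h (on this read-out lower numbers stand for stronger inhibition and higher numbers for weaker inhibition), at a limit of the assay, > 150000 nM. Compound 2 `CCOC(=O)C1=Cc2ccccc2OC1(OCc1cc(-c2ccc([N+](=O)[O-])cc2)no1)C(F)(F)F` likewise gives only a limit in this assay, > 150000 nM. Both entries rest at the limit of > 150000 nM in this assay, at which 2 of the 2 values shown sit, so compound 1 stands nowhere distinct among the numbers shown. Compound 3 `CCOC(=O)C1=Cc2ccccc2OC1(OCc1cn(-c2ccc([N+](=O)[O-])cc2)nn1)C(F)(F)F` differs from compound 1 by 4-nitrophenyl in place of 3-methoxyphenyl on an aromatic nitrogen. Within the data shown here, no step between measured compounds exists here; the step in this assay that the estimate means, a step that the limit leaves unreadable from compound 1 to compound 3, is expected to be none beyond the scatter, most likely another limit. For compound 3 the estimate in this assay is 200000 nM, between 100000 nM and 500000 nM.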

Compound 3, half-maximal inhibitory concentration: > 150000 nM
Compound 3: only a limit was reported; the forecaster's own chance of this, stated with the estimate: 85%; the middle value does not contradict the limit.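

No step can be read from compound 1 to compound 3, as both rest at a limit in this assay: the limit of > 150000 nM in this assay, at which 3 of the 3 values shown sit.

The compounds shown leave open whether any change on the shared core gives a measurable value in this assay.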